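The source may report more compounds than this note shows. Statements on the series, on what has been measured and on what is new or still open speak of the compounds shown alone.

Compound 2 `COc1cc(-c2nn(-c3cccc(NC(=O)c4cccc(C(F)(F)F)c4)c3)cc2-c2ccncc2)ccc1Cl` stands at a limit in a functional assay on SF-539 cells (Homo sapiens) for inhibition, read by sulforhodamine B assay, with a stated time of 48 h (a higher number here means that more compound is tolerated, a lower number that less compound is tolerated), reported as > 50000 nM, so for it only a limit and no number is known (the limit of > 50000 nM in this assay, at which 1 of the 3 values shown sits). Compound 1 `COc1cc(-c2nn(-c3cccc(NC(=O)Nc4cc(C(F)(F)F)cc(C(F)(F)F)c4)c3)cc2-c2ccncc2)ccc1Cl` gives 3540 nM in this assay, and compound 3 `O=C(Nc1cccc(-n2cc(-c3ccncc3)c(-c3ccc(Cl)c(O)c3)n2)c1)Nc1cc(C(F)(F)F)cc(C(F)(F)F)c1` gives 2890 nM; the step of a 1.2-fold lower number from compound 1 to compound 3 (0.09 log units; within the scatter) is small. Compound 4 `COc1cc(-c2nn(-c3cccc(NC(=O)Nc4ccc(Cl)c(C(F)(F)F)c4)c3)cc2-c2ccncc2)ccc1Cl` differs from compound 2 by (4-chloro-3-(trifluoromethyl)phenyl)amino in place of 3-(trifluoromethyl)phenyl on a carbonyl carbon, which makes it a urea like compound 1 and compound 3. Among the compounds with values here, no measured step covers this change alone. Compound 1 and compound 3, both ureas, show numbers rather than limits. Compound 4 is expected to show a number as well, an expected step of an at least 12-fold lower number from compound 2 to compound 4 (1.09 log units; beyond the scatter). The estimate for compound 4 is 4000 nM, with a range from 1500 nM to 15000 nM.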

Compound 4, concentration lethal to 50% of the cells: 17500 nM
The estimate for compound 4 lay 4.4-fold (0.64 log units) below the measured number, outside the stated range (above it).
By their numbers in this assay, from the lowest: compounds 3 and 1 (each within the scatter of the next); then compound 4. At a limit, above all of these: compound 2.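

The change on the carbonyl carbon, (4-chloro-3-(trifluoromethyl)phenyl)amino in place of 3-(trifluoromethyl)phenyl, brings a real number into reach in this assay, with an at least 2.8-fold lower number from compound 2 to compound 4 (0.45 log units; beyond the scatter). On these data alone, compound 2 is only a limit, so the true size of this step stays unknown: the limit of > 50000 nM in this assay, at which 1 of the 4 values shown sits. Compound 4, at 17500 nM, still has a higher number than compound 1, at 3540 nM, so the urea alone does not fix the value. As far as these compounds go, the step adds the amino nitrogen and the chlorine together, and their separate shares remain open. Also open, from the compounds shown here alone, is what a urea carrying a morpholine or a carboxylic acid in place of that aromatic ring would give.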